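The source may report more compounds than this note shows. Statements on the series, on what has been measured and on what is new or still open speak of the compounds shown alone.

Two compounds have numbers in a functional assay on NCI-H460 cells (Homo sapiens) for cytotoxicity, read by MTT assay, with a stated time of 72 h; on this read-out higher numbers stand for weaker inhibition and lower numbers for stronger inhibition. Compound 1 `COc1cc2c(Oc3ccc(NC(=O)c4cn(-c5c(C)cccc5C)nn4)cc3F)ccnc2cc1OCCCN1CCCC1` gives 1560 nM in this assay, and compound 2 `COc1cc2c(Oc3ccc(NC(=O)c4cn(-c5ccccc5F)nn4)cc3F)ccnc2cc1OCCCN1CCCCC1` gives 210 nM. Of these two, compound 2 has the lower number, and its gap to compound 1 lies beyond the scatter. Compound 3 `COc1cc2c(Oc3ccc(NC(=O)c4cn(-c5c(C)cccc5C)nn4)cc3F)ccnc2cc1OCCCN1CCCCC1` differs from compound 2 by 2,6-dimethylphenyl in place of 2-fluorophenyl on an aromatic nitrogen. For the measured compounds named here, no step of that kind between measured compounds is known. The expectation is that the step from compound 2 to compound 3 in this assay is a 4.3-fold higher number from compound 2 to compound 3 (0.63 log units; beyond the scatter), moving to a higher number, beyond the scatter. Compound 3 is therefore estimated at 900 nM, with a range from 300 nM to 3000 nM.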

Compound 3, half-maximal inhibitory concentration: 3520 nM
The estimate for compound 3 lay 3.9-fold (0.59 log units) below the measured number; the whole stated range lies below it.
By their numbers in this assay, from the lowest: compound 2; then compound 1; then compound 3.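

In this assay, the aryl group on the aromatic nitrogen proves a sensitive point: 2,6-dimethylphenyl in place of 2-fluorophenyl gives a 17-fold higher number from compound 2 to compound 3 (1.22 log units; beyond the scatter). For the compounds shown here, with 2,6-dimethylphenyl held fixed, piperidin-1-yl in place of pyrrolidin-1-yl gives a modest 2.3-fold higher number from compound 1 to compound 3 (0.35 log units; beyond the scatter), the first reading of the amine at the end of the chain. Nothing available explains either step. As far as these compounds go, whether the aryl step would keep its size with pyrrolidin-1-yl on the chain stays open. So does how an unsubstituted phenyl, a 2-methylphenyl or a morpholin-4-yl group would read.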